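Halogen Swap on the Fused Ring: Bromo to Chloro

The compounds below may be only part of what the source reports. "The series", "measured", "known", "first", "only" and "open" are said of these compounds alone.

Compound 1 `COc1ccc(C2=NN(C3=NC(=O)/C(=C4\C(=O)Nc5ccc(Cl)cc54)S3)C(c3ccc(OC)cc3)C2)cc1`: 710 nM
Compound 2 `COc1ccc(C2=NN(C3=NC(=O)/C(=C4\C(=O)Nc5ccccc54)S3)C(c3ccc(Cl)cc3)C2)cc1`: 100000 nM
Compound 3 `COc1ccc(C2=NN(C3=NC(=O)/C(=C4\C(=O)Nc5ccc(Br)cc54)S3)C(c3ccc(Cl)cc3)C2)cc1`: 1010 nM

In a functional assay on cells (Cancer cell lines, Homo sapiens) for cytotoxicity, read by sulforhodamine B assay, with a stated time of 48 h (on this read-out lower numbers stand for stronger inhibition of growth and higher numbers for weaker inhibition of growth), compound 3 gives 1010 nM, the second highest of the three numbers. Its nearest neighbour is compound 1, which in this assay gives 710 nM, a gap within the usual scatter. Its furthest is compound 2, which in this assay gives 100000 nM, a gap far beyond the scatter.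

Compound 4 `COc1ccc(C2=NN(C3=NC(=O)/C(=C4\C(=O)Nc5ccc(Cl)cc54)S3)C(c3ccc(Cl)cc3)C2)cc1` has not yet been measured. It differs from compound 3 by chloro in place of bromo on an aromatic carbon. Among the compounds with values here, one measured step bears on this position: a 99-fold lower number from compound 2 to compound 3 (2.00 log units; beyond the scatter) shows that placing a halogen on this aromatic carbon mattered greatly when the alternative was hydrogen. Whether the identity of the halogen matters is not directly measured. Compound 1 carries chloro at the same place as compound 4, though with a different group on the other aryl ring, and its value sits within the scatter of compound 3. Taken together, a step within the scatter is expected for this assay, with no clear direction. Compound 4 is therefore expected to give about 800 nM, between 300 nM and 2500 nM, which would mean a step of a 1.3-fold lower number from compound 3 to compound 4 (0.10 log units; within the scatter).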

Compound 4, concentration for total growth inhibition: 740 nM
Compound 4: the middle estimate sits 1.1-fold (0.03 log units) above what was measured; low and high end bracket the measured number.
By their numbers in this assay, from the lowest: compounds 1, 4 and 3 (each within the scatter of the next); then compound 2.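

In this assay, the new result shows that the identity of the halogen at this aromatic carbon makes no measurable difference between these two, since a 1.4-fold lower number from compound 3 to compound 4 (0.14 log units; within the scatter) stays within the scatter. The large effect seen earlier with bromo therefore does not belong to bromo alone, as chloro in place of hydrogen also gives a large step, with a 140-fold lower number from compound 2 to compound 4 (2.13 log units; beyond the scatter) standing beside a 99-fold lower number from compound 2 to compound 3 (2.00 log units; beyond the scatter). Within the data shown here, with chloro fixed at this position, the change on the other aryl ring also stays within the scatter, with a 1.0-fold higher number from compound 1 to compound 4 (0.02 log units; within the scatter) for chloro in place of methoxy, so that swap shows no effect in this pair.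

The compounds shown leave open whether the large step needs a halogen at all, or whether an amine, a carboxylic acid or a fluoro group on this aromatic carbon would also give numbers close to those of the chloro and bromo compounds. No accompanying measurement is available to explain why hydrogen and the two halogens differ so sharply here.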